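The source may hold more compounds than are shown below. What is called first, only, known or untested is meant among the compounds shown, and "the series" means these compounds.

Two urea-linked compounds carrying the same shared core have been measured. Compound 1 (`CN(C)CCn1cnnc1-c1cc(Oc2ccc(NC(=O)Nc3cccc(C(F)(F)F)c3)cc2F)ccn1`) carries a 3-(trifluoromethyl)phenyl on the urea and a two-carbon chain on the triazole; in a functional assay on HT-29 cells (Homo sapiens) for antiproliferative activity, read by MTT assay, with a stated time of 72 h (on this read-out lower numbers stand for stronger inhibition and higher numbers for weaker inhibition), compound 1 gives 1470 nM. Compound 2 (`CN(C)CCCn1cnnc1-c1cc(Oc2ccc(NC(=O)Nc3ccc(Cl)c(C(F)(F)F)c3)cc2F)ccn1`) carries a 4-chloro-3-(trifluoromethyl)phenyl and a three-carbon chain; in this assay compound 2 gives 1400 nM. The two numbers lie within the scatter of each other, so compound 2 stands level with compound 1 and no ordering between them can be drawn.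

Compound 3 (`CN(C)CCCn1cnnc1-c1cc(Oc2ccc(NC(=O)Nc3cccc(C(F)(F)F)c3)cc2F)ccn1`) has not been measured. It differs from compound 2 in one place: hydrogen in place of chloro on an aromatic carbon, on the aromatic carbon that is para to the large group and ortho to the trifluoromethyl group. Among the measured compounds shown here, no step between two measured compounds isolates this change. Taking away the chloro while the three-carbon chain stays is expected to cost little, with a step from compound 2 to compound 3 of a 1.4-fold higher number from compound 2 to compound 3 (0.15 log units; within the scatter), which is not beyond the scatter. Compound 3 is therefore estimated at 2000 nM in this assay, within a range of 800 nM to 5000 nM.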

Compound 3, half-maximal inhibitory concentration: 980 nM
For compound 3 the middle estimate is 2.0-fold (0.31 log units) above the measured one; the measured number falls inside the stated range.
By their numbers in this assay, from the lowest: compounds 3, 2 and 1 (each within the scatter of the next).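

Among the compounds shown here, compound 3 reads this position on its own for the first time: with everything else held fixed, hydrogen in place of chloro on the aromatic carbon ortho to a trifluoromethyl group and para to a large group gives in this assay a 1.4-fold lower number from compound 2 to compound 3 (0.15 log units; within the scatter) and thus no measurable change. It also isolates the chain, since with the 3-(trifluoromethyl)phenyl held fixed, (dimethylamino)methyl in place of dimethylamino on a saturated chain carbon gives a 1.5-fold lower number from compound 1 to compound 3 (0.18 log units; within the scatter) and likewise stays inside the scatter. Compound 1 and compound 2 differ in both places, so their level readings could have hidden two larger opposing steps, but neither single step shows one. Nothing measured beyond these numbers bears on the result.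

As far as these compounds go, whether a group other than chloro at this position, such as a methoxy, a nitrile or a bromine, would give a step beyond the scatter remains open. So does the outcome of a longer chain, or of a morpholine in place of the dimethylamino group, in this assay and in any other read-out.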